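The compounds below may be only part of what the source reports. "The series", "measured", "known", "first", "only" and "open" are said of these compounds alone.

Two members of the series carry values in an assay on isolated protein for inhibition of protein deacetylase HDAC6 (Homo sapiens), read by fluorescence, with a stated time of 15 min; a lower number here means a stronger inhibitor, a higher number a weaker inhibitor. Compound 1 `O=C(NO)c1cccc(/C=C/c2ccnc(-c3cc(F)ccc3O)c2)c1` gives 400 nM. Compound 2 `COc1ccccc1-c1cc(/C=C/c2ccc(C(=O)NO)cc2)ccn1` gives 28 nM, the lowest of the two numbers, with compound 1 standing above it by a gap beyond the usual scatter. For the measured compounds named here, the two differ in more than one place, so no single step is drawn between them. Compound 3 `O=C(NO)c1ccc(/C=C/c2ccnc(Br)c2)cc1` is not yet measured. It differs from compound 2 in one place: bromo in place of 2-methoxyphenyl on an aromatic carbon. Going by the values given here, no measured pair isolates this change. Among the compounds with values here, the only guide is the comparison of compound 1, which carries a different substituent at that place and differs from compound 2 in other respects as well, with compound 2 itself: in this assay compound 1 gives 400 nM, while compound 2 gives 28 nM. Replacing the 2-methoxyphenyl with the single bromine is expected to raise the number. The step of a 3.9-fold higher number from compound 2 to compound 3 (0.59 log units; beyond the scatter) is expected to be a moderate weakening. Compound 3 is estimated at 110 nM, within 40 nM to 320 nM.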

Compound 3, half-maximal inhibitory concentration: 320 nM
Estimate against measurement, compound 3: 2.9-fold (0.46 log units) below; measured number inside the range.
By their numbers in this assay, from the lowest: compound 2; then compounds 3 and 1 (each within the scatter of the next).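

In this assay, replacing 2-methoxyphenyl with bromo on the aromatic carbon next to the ring nitrogen gives an 11-fold higher number from compound 2 to compound 3 (1.06 log units; beyond the scatter), a large step. For the compounds shown here, this is the first pair to isolate a change at this position, and it shows that the number depends strongly on the substituent there, with the 2-methoxyphenyl going with the stronger inhibitor of the two. Nothing at hand accounts for the size of this step.

Whether the difference belongs to the aromatic ring or to its methoxy group remains open: phenyl without the methoxy, and small groups such as methyl or an amine at this position, are not among the compounds shown. One pair also cannot tell whether the step carries over to the core of compound 1.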